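A few compounds are considered here, and "the series" means these few. Any claim that something is new, unique, unknown or untested is made for them only; others in the source may bear on it.

Measured in a functional assay on MDA-MB-436 cells (Homo sapiens) for antiproliferative activity, read by MTT assay, with a stated time of 48 h; on this read-out higher numbers stand for weaker inhibition and lower numbers for stronger inhibition:
- compound 1 `CN1CCN(c2ccc(-c3cc4c(N5CCN(S(=O)(=O)C6CC6)CC5)ncnc4s3)cc2)CC1`: 10600 nM
- compound 2 `CN1CCN(c2ccc(-c3cc4c(N5CCN(C(=O)Nc6ccc(Cl)cc6)CC5)ncnc4s3)cc2)CC1`: 9270 nM

For the measured compounds named here, compound 2 stands level with compound 1, the only other measured compound, since the step of a 1.1-fold lower number from compound 1 to compound 2 (0.06 log units; within the scatter) lies within the scatter. Compound 3 `CN1CCN(c2ccc(-c3cc4c(N5CCN(C(=O)Nc6ccc(Cl)c(C(F)(F)F)c6)CC5)ncnc4s3)cc2)CC1` keeps all of compound 2 but adds one change: trifluoromethyl in place of hydrogen on an aromatic carbon. Trifluoromethyl replaces hydrogen on an aromatic carbon, ortho to a chloro group, which turns 4-chlorophenyl into 4-chloro-3-(trifluoromethyl)phenyl. Going by the values given here, no measured step touches this aromatic carbon. Among the compounds with values here, the single step available, a 1.1-fold lower number from compound 1 to compound 2 (0.06 log units; within the scatter), exchanged a whole group on the ring nitrogen and gives only weak guidance. A small shift towards a lower number is therefore expected in this assay, possibly none beyond the scatter. The expected step is a 1.5-fold lower number from compound 2 to compound 3 (0.19 log units; within the scatter). For compound 3 the estimated value is 6000 nM, with an expected range from 2000 nM to 13000 nM.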

Compound 3, half-maximal inhibitory concentration: 3500 nM
Beside the measured number, compound 3's estimate is 1.7-fold (0.23 log units) above it; the range from low to high includes it.
By their numbers in this assay, from the lowest: compound 3; then compounds 2 and 1 (each within the scatter of the next).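

In this assay, for the compounds shown here, the exchange of a whole group on the ring nitrogen left the number within the scatter, whereas this much smaller change on the aromatic ring gives a 2.6-fold lower number from compound 2 to compound 3 (0.42 log units; beyond the scatter) and is the first step here to pass beyond it. The aromatic carbon ortho to a chloro group is thus a place where substitution can alter the read-out, although the shift is modest and rests on this single pair. Nothing available explains why this change lowers the number.

The compounds shown leave open whether trifluoromethyl itself matters or whether a methyl group, a nitrile or a methoxy group on the same carbon would serve equally well. They also leave open whether the step depends on the chloro group, since 3-(trifluoromethyl)phenyl without chlorine does not appear among them.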